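A few compounds are considered here, and "the series" means these few. Any claim that something is new, unique, unknown or untested is made for them only; others in the source may bear on it.

Three compounds have been measured in a functional assay on HeLa cells (Homo sapiens) for antiproliferative activity, read by CCK-8 assay, with a stated time of 72 h, tested at 2 uM; on this read-out lower numbers stand for a weaker effect and higher numbers for a stronger effect at the one concentration tested:
compound 1 `Nc1ccccc1NC(=O)c1ccc(CSC(=S)N2CCN(c3ccc(Cl)cc3)CC2)cc1` gives 51.2%;
compound 2 `CN(C(=S)SCc1ccc(C(=O)Nc2ccccc2N)cc1)c1cccnc1` gives 16%;
compound 3 `COc1ccc(N2CCN(C(=S)SCc3ccc(C(=O)Nc4ccccc4N)cc3)CC2)cc1` gives 39.4%.

Compound 2 stands lowest of the three numbers. Its nearest neighbour is compound 3, and the gap between them lies beyond the scatter, as does the larger gap to compound 1. All three share the same core, and they differ only in the amine attached to the thiocarbonyl carbon.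

The unmeasured compound 4 `CCN(Cc1ccncc1)C(=S)SCc1ccc(C(=O)Nc2ccccc2N)cc1` is reached from compound 2 by one change: ethyl((pyridin-4-yl)methyl)amino in place of methyl(pyridin-3-yl)amino on a thiocarbonyl carbon. For the measured compounds named here, only one measured step is available, a number 11.8 percentage points lower from compound 1 to compound 3 (beyond the scatter), and it concerns a methoxy in place of chloro on an aromatic carbon in a different part of the molecule, so it says little about the swap of one amine for another at the thiocarbonyl carbon. Going by the values given here, no measured pair tells how an amine of this kind compares with methyl(pyridin-3-yl)amino, and compound 2 is the only measured compound whose amine is not an aryl piperazine. The step into compound 4 is therefore expected to stay within the scatter, with at most a small rise, so that a number 6 percentage points higher from compound 2 to compound 4 (within the scatter) is expected. Compound 4 is estimated at 22%, in a range from 8% to 40%.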

Compound 4, a percentage reported as inhibition, at one concentration (the size of the read-out at that concentration, not a potency): 63.5%
Compound 4: middle estimate off by 41.5 percentage points, on the low side; the whole stated range lies below it.
By their numbers in this assay, from the lowest: compound 2; then compound 3; then compound 1; then compound 4.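

For the compounds shown here, the amine on the thiocarbonyl carbon proved to be a highly sensitive position in this assay: the change to ethyl((pyridin-4-yl)methyl)amino gave a number 47.5 percentage points higher from compound 2 to compound 4 (beyond the scatter), whereas the only earlier step came from a change elsewhere in the molecule. Compound 4 also shows that the low reading of compound 2 does not extend to every amine outside the aryl piperazine type, since compound 4, which likewise has no piperazine, gives 63.5% on the same shared core. Nothing available accounts for the size of this step.

The change replaces methyl with ethyl and pyridin-3-yl with (pyridin-4-yl)methyl in one move, so these compounds cannot show which part of it carries the rise; methyl((pyridin-4-yl)methyl)amino and ethyl((pyridin-3-yl)methyl)amino would separate those parts. From the compounds shown here alone, it also remains open whether the high reading depends on the pyridine ring at all, a question that benzyl(ethyl)amino at the same thiocarbonyl carbon would address, and whether it would persist in a full dose-response measurement rather than at the one concentration tested.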